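The compounds below may be only part of what the source reports. "The series", "measured", "known", "first", "only" and "open" are said of these compounds alone.

Of the compounds shown here, two sharing one core have been tested so far. Compound 1 `COc1cc(-c2nn(-c3cccc(NC(=O)Nc4cc(C(F)(F)F)cc(C(F)(F)F)c4)c3)cc2-c2ccncc2)ccc1Cl` gives 5310 nM in a functional assay on SNB-75 cells (Homo sapiens) for inhibition, read by sulforhodamine B assay, with a stated time of 48 h; on this read-out lower numbers stand for higher toxicity in this test and higher numbers for lower toxicity in this test. Compound 2 `COc1cc(-c2nn(-c3cccc(NC(=O)Nc4cccc(C(F)(F)F)c4)c3)cc2-c2ccncc2)ccc1Cl` differs from it by a hydrogen in place of one trifluoromethyl group, and in this assay compound 2 gives 50000 nM. That single change produced a 9.4-fold higher number from compound 1 to compound 2 (0.97 log units; beyond the scatter), so compound 2 stands at the higher of the two numbers, the less toxic end.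

Compound 3 `COc1cc(-c2nn(-c3cccc(NC(=O)c4ccccc4)c3)cc2-c2ccncc2)ccc1Cl` is not yet measured. It differs from compound 2 by phenyl in place of (3-(trifluoromethyl)phenyl)amino on a carbonyl carbon. Among the measured compounds shown here, the only measured step, from compound 1 to compound 2, shows that removing a trifluoromethyl group on this aromatic ring moved the number up. Compound 3 removes the remaining trifluoromethyl group and the attached amino group as well, so a further rise in this assay, or at least no fall, is expected. Compound 3 is therefore estimated at 70000 nM, within 20000 nM to 200000 nM, a step of a 1.4-fold higher number from compound 2 to compound 3 (0.15 log units; within the scatter).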

Compound 3, concentration lethal to 50% of the cells: > 100000 nM
Compound 3: no number, only a limit (the forecaster's own chance of this, stated with the estimate: 40%); middle value at least 1.4-fold (0.15 log units) from the limit.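

In this assay compound 3 gives > 100000 nM, which is a limit of the assay and not a number. Putting phenyl in place of (3-(trifluoromethyl)phenyl)amino on the carbonyl carbon gives an at least 2.0-fold higher number from compound 2 to compound 3 (0.30 log units; that floor lies within the scatter), so the earlier step on the trifluoromethyl group is now joined by a larger change, the loss of the whole group with its amino nitrogen, and this brings no sign of higher toxicity in this test. How far the number really moved stays unknown, and the reading reaches the ceiling of the test: the limit of > 100000 nM in this assay, at which 1 of the 3 values shown sits.

The compounds shown leave open which part of the change counts, as the amino nitrogen and the trifluoromethyl group go in the same step. Also open, from the compounds shown here alone, is how plain phenylamino, or a saturated amine such as piperidine, on that carbonyl carbon would read in this assay.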